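A few compounds are considered here, and "the series" means these few. Any claim that something is new, unique, unknown or untested is made for them only; others in the source may bear on it.

Compound 1, `O=C(/C=C\c1ccccc1O)N1N=C(c2ccncc2)OC1c1c[nH]c2ccccc12`, gives 26.8 ug/mL in an ADME assay on HeLa cells (Homo sapiens) for cytotoxicity, read by MTT assay, with a stated time of 72 h; a higher number here means a weaker inhibitor of growth, a lower number a stronger inhibitor of growth.
Compound 2, `O=C(/C=C\c1cccc(O)c1)N1N=C(c2ccncc2)OC1c1c[nH]c2ccccc12`, gives > 30 ug/mL in this assay, which is a limit of the assay rather than a number.
Compound 3, `O=C(/C=C\c1ccc(O)cc1)N1N=C(c2ccncc2)OC1c1c[nH]c2ccccc12`, gives > 30 ug/mL in this assay, again a limit rather than a number.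

Compound 2 therefore stands at the edge of what this assay can report, and the limit of > 30 ug/mL in this assay, at which 2 of the 3 values shown sit, shows that it is not alone there. Compound 4, `O=C(/C=C\c1ccccc1[N+](=O)[O-])N1N=C(c2ccncc2)OC1c1c[nH]c2ccccc12`, differs from compound 2 in one place: 2-nitrophenyl in place of 3-hydroxyphenyl on a double-bonded chain carbon bound to a double-bonded chain carbon. Within the data shown here, no measured step swaps a hydroxyl-bearing ring for a nitro-bearing one, so the only guidance comes from moving the hydroxyl around the ring. The step of an at least 1.1-fold higher number from compound 1 to compound 2 (0.04 log units; that floor lies within the scatter) stays within the scatter, and the step that the two limits leave unreadable from compound 2 to compound 3 cannot be read at all because both ends sit at the limit. Nothing here points to a step beyond the scatter in either direction for compound 4 in this assay. Compound 4 is thus expected to give about 30 ug/mL, within a range from 14 ug/mL to 65 ug/mL. The step this estimate implies, a number no higher from compound 2 to compound 4 (the limit leaves the size open), is an expectation and may well end as another limit.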

Compound 4, concentration for 50% growth inhibition: > 30 ug/mL
Compound 4: only a limit was reported; the forecaster's own chance of this, stated with the estimate: 60%; the middle value sits exactly at the limit.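

Nitro in place of hydroxy on an aromatic carbon gives an at least 1.1-fold higher number from compound 1 to compound 4 (0.04 log units; that floor lies within the scatter), so the first change here that replaces the hydroxyl with a different group shows no step beyond the scatter in this assay. The steps from compound 2 and from compound 3 to compound 4 cannot be read, as both ends of each are limits. With 2-nitrophenyl on a double-bonded chain carbon, the limit now holds for a ring without a hydroxyl as well as for two rings with one, and compound 1 alone goes against this pattern by giving a number: the limit of > 30 ug/mL in this assay, at which 3 of the 4 values shown sit.

Going by these compounds, whether an amine or a carboxylic acid on this ring would give a number clearly under the limit stays open. Also open, on these data alone, is how far compound 2, compound 3 and compound 4 truly lie beyond it.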